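Hydrogen for Isopropyl on the Shared Core

The source may hold more compounds than are shown below. What is called first, only, known or untested is meant among the compounds shown, and "the series" means these compounds.

Compound 3 `CC(C)n1ncc2c(NCc3ccccc3[N+](=O)[O-])cc(C(F)(F)F)cc21` stands in an assay for inhibition of Indoleamine 2,3-dioxygenase 1 (Homo sapiens), with stated times of 10 min and 60 min (a lower number here means a stronger inhibitor, a higher number a weaker inhibitor), only at a limit of the assay, giving > 100000 nM. Compound 1 `O=[N+]([O-])c1cc(OCc2ccccc2)ccc1CNc1cc(C(F)(F)F)cc2[nH]ncc12` likewise gives only a limit, > 100000 nM. For compound 2 `O=[N+]([O-])c1ccccc1CNc1cccc2[nH]ncc12` this assay records "nd" (no result reported), so no number is reported. Within the data shown here, two of the three entries thus sit at the limit of > 100000 nM in this assay, at which 2 of the 3 values shown sit, and no step between measured compounds can be drawn. Compound 4 `O=[N+]([O-])c1ccccc1CNc1cc(C(F)(F)F)cc2[nH]ncc12` differs from compound 3 by hydrogen in place of isopropyl on an aromatic nitrogen. Compound 1 carries the same hydrogen at this place and remains at a limit. The expected step is therefore a step that the limit leaves unreadable from compound 3 to compound 4, none beyond the scatter. Compound 4 is estimated at 150000 nM, within 30000 nM to 1000000 nM.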

Compound 4, half-maximal inhibitory concentration: 14000 nM
Estimate against measurement, compound 4: 11-fold (1.03 log units) above, outside the stated range (below it).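

Hydrogen in place of isopropyl on the aromatic nitrogen gives, in this assay, an at least 7.1-fold lower number from compound 3 to compound 4 (0.85 log units; beyond the scatter), the first readable effect of a change at this place. Hydrogen in place of benzyloxy on an aromatic carbon gives an at least 7.1-fold lower number from compound 1 to compound 4 (0.85 log units; beyond the scatter), which leaves compound 4 as the only compound shown with a number rather than a limit. Both steps give only a minimum size, because each starts from a limit: the limit of > 100000 nM in this assay, at which 2 of the 4 values shown sit.

From the compounds shown here alone, their true sizes remain open. So does how a methyl on that nitrogen, or a methoxy in place of benzyloxy, would read.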